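Changing the sulfonyl substituent on a prostaglandin receptor ligand

The compounds below may be only part of what the source reports. "The series", "measured", "known", "first", "only" and "open" are said of these compounds alone.

In an assay on CHO cells for displacement of a labelled ligand from prostaglandin D2 receptor 2 (Homo sapiens), read by scintillation counting (a higher number here means a weaker inhibitor, a lower number a stronger inhibitor), compound 3 `CCS(=O)(=O)c1ccc(C)c(C#Cc2cc(Cl)ccc2OCC(=O)O)c1` gives 8.6 nM, the highest of the three numbers, though its gap to compound 1 lies within the scatter. Compound 1 `Cc1ccc(S(C)(=O)=O)cc1C#Cc1cc(Cl)ccc1OCC(=O)O` gives 5 nM and compound 2 `CCN(CC)S(=O)(=O)c1ccc(C)c(C#Cc2cc(Cl)ccc2OCC(=O)O)c1` gives 3.4 nM. Compound 4 `Cc1ccc(S(=O)(=O)NC(C)(C)C)cc1C#Cc1cc(Cl)ccc1OCC(=O)O` differs from compound 3 only on the sulfonyl sulfur: (tert-butyl)amino in place of ethyl on a sulfonyl sulfur. The step that bears most on this runs the other way, a 2.5-fold higher number from compound 2 to compound 3 (0.40 log units; beyond the scatter), where diethylamino left; a 1.5-fold lower number from compound 1 to compound 2 (0.17 log units; within the scatter) brought diethylamino in. Both point to a lower number when a nitrogen-bearing group sits on the sulfonyl sulfur, so a modest fall in this assay is expected, a 2.2-fold lower number from compound 3 to compound 4 (0.33 log units; beyond the scatter). Compound 4 is therefore estimated at 4 nM, within a range from 1.5 nM to 12 nM.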

Compound 4, inhibition constant: 5 nM
Compound 4: the middle estimate sits 1.3-fold (0.10 log units) below what was measured, and the stated range covers the measured number.
By their numbers in this assay, from the lowest: compounds 2, 1, 4 and 3 (each within the scatter of the next, the first and the last beyond it).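

In this assay the (tert-butyl)amino group on the sulfonyl sulfur stays level with the other three groups, with a 1.7-fold lower number from compound 3 to compound 4 (0.24 log units; within the scatter) and a 1.5-fold higher number from compound 2 to compound 4 (0.17 log units; within the scatter) and no change at the digits printed from compound 1 to compound 4 (within the scatter) all showing no clear difference. A nitrogen on this sulfur therefore does not by itself set a compound apart from the ethyl compound, and this place accepts a group of 5 heavy atoms carrying 1 hydrogen-bond donor. Nothing available explains this result. From the compounds shown here alone, whether a piperidine ring on the sulfonyl sulfur, or a longer chain ending in a carboxylic acid, would keep this level remains open.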